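Cytotoxicity in Raji cells: biaryl amide hexanoate series

The source may hold more compounds than are shown below. What is called first, only, known or untested is meant among the compounds shown, and "the series" means these compounds.

Measured so far:
- Compound 1, `CC(C)N(Cc1cccc(OCCCCCC(=O)O)c1)C(=O)c1ccc(-c2cccc(S(C)(=O)=O)c2)cc1`. In an ADME assay on Raji cells (Homo sapiens) for cytotoxicity, read by CellTiter-Glo and resazurin assay, with a stated time of 72 h (on this read-out higher numbers stand for an effect only at larger amounts of compound and lower numbers for an effect already at smaller amounts), compound 1 gives > 26000 nM, which is a limit of the assay and not a number.
- Compound 2, `CCOC(=O)CCCCCOc1cccc(CN(C(=O)c2ccc(-c3cccnc3)cc2)C(C)C)c1`. In this assay compound 2 gives > 26000 nM, again a limit and not a number.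

Compound 2 therefore stands at the top of what the read-out can report, together with compound 1: the limit of > 26000 nM in this assay, at which 2 of the 2 values shown sit. Within the data shown here, with both values limits, no step between the measured compounds can be stated, and no value tells how far either compound lies beyond the limit.

The next compound, compound 3, `CCOC(=O)CCCCCOc1cccc(CN(C(=O)c2ccc(-c3ccc4cc[nH]c4c3)cc2)C(C)C)c1`, is to be measured in this assay. It differs from compound 2 in one place: 1H-indol-6-yl in place of pyridin-3-yl on an aromatic carbon. Nothing measured in the series bears on the indol-6-yl group, so the expectation rests on the limit of compound 2 alone. The step that the limit leaves unreadable from compound 2 to compound 3 is expected to be none beyond the scatter, with the result most likely reported again as a limit. Compound 3 is expected at 30000 nM, with a range from 8000 nM to 100000 nM.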

Compound 3, half-maximal effective concentration: > 26000 nM
Compound 3: a limit, no number; the forecaster's own chance of this, stated with the estimate: 70%; the middle value is on the limit's open side.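

Compound 3 gives > 26000 nM, which is a limit and not a number. No step can be read from compound 2 to compound 3, as both results are limits: the limit of > 26000 nM in this assay, at which 3 of the 3 values shown sit.

The compounds shown leave open how far each lies beyond the limit, and whether 1H-indol-6-yl in place of pyridin-3-yl changes the read-out at all.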